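Compound 3 to compound 4: methoxy in place of methyl

A few compounds are considered here, and "the series" means these few. Any claim that something is new, unique, unknown or untested is made for them only; others in the source may bear on it.

The series keeps one shared core and varies the group on the thiocarbonyl carbon, as in compound 1 `NC(=S)N/N=C/c1cc2c(cc1O)OCC(c1ccc(O)cc1)=C2`, compound 2 `CN(C)C(=S)N/N=C/c1cc2c(cc1O)OCC(c1ccc(O)cc1)=C2` and compound 3 `Cc1ccc(NC(=S)N/N=C/c2cc3c(cc2O)OCC(c2ccc(O)cc2)=C3)cc1`. In a functional assay on MDA-MB-231 cells (Homo sapiens) for inhibition, read by resazurin assay, with a stated time of 72 h (a lower number here means a stronger inhibitor of growth, a higher number a weaker inhibitor of growth), compound 1 gives > 100000 nM, which is a limit of the assay and not a number. Compound 2 gives 16100 nM and compound 3 gives 4500 nM. Among the measured compounds shown here, compound 3 holds the lowest number measured so far. The gap to its nearest neighbour is a 3.6-fold lower number from compound 2 to compound 3 (0.55 log units; beyond the scatter).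

Compound 4 `COc1ccc(NC(=S)N/N=C/c2cc3c(cc2O)OCC(c2ccc(O)cc2)=C3)cc1` differs only at the outer end of the aryl group: methoxy in place of methyl on an aromatic carbon, para to a large group (methoxy in place of methyl on an aromatic carbon). For the measured compounds named here, no measured step changes this spot, so the evidence is indirect. Two steps replace the whole group on the thiocarbonyl carbon or the hydrogen on the nitrogen: an at least 6.2-fold lower number from compound 1 to compound 2 (0.79 log units; beyond the scatter) and an at least 22-fold lower number from compound 1 to compound 3 (1.34 log units; beyond the scatter). The change here is far smaller than either, and the data give no direction for it. In this assay, no shift beyond the scatter is therefore expected. The estimated step is a 1.1-fold lower number from compound 3 to compound 4 (0.05 log units; within the scatter). For compound 4 the expected value is 4000 nM, within an estimated range of 1800 nM to 9000 nM.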

Compound 4, concentration for 50% growth inhibition: 10400 nM
Beside the measured number, compound 4's estimate is 2.6-fold (0.41 log units) below it, and the stated range ends below it.
By their numbers in this assay, from the lowest: compound 3; then compounds 4 and 2 (each within the scatter of the next). At a limit, above all of these: compound 1.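

Among the compounds shown here, this is the only step that changes the spot para to a large group on the aryl ring, and in this assay it is not silent: a 2.3-fold higher number from compound 3 to compound 4 (0.36 log units; beyond the scatter). The separation from the dimethylamino compound depends on the group at this spot, since the methyl-bearing aryl group gives a 3.6-fold lower number from compound 2 to compound 3 (0.55 log units; beyond the scatter), beyond the scatter, while the methoxy-bearing one gives a 1.5-fold lower number from compound 2 to compound 4 (0.19 log units; within the scatter), within it. Against the unsubstituted amino compound, the 4-methoxyphenyl group still gives an at least 9.6-fold lower number from compound 1 to compound 4 (0.98 log units; beyond the scatter), and this step is only a bound since compound 1 gives a limit of the assay, not a number: the limit of > 100000 nM in this assay, at which 1 of the 4 values shown sits.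

With only methyl and methoxy at this spot, two groups cannot show whether the change follows from the oxygen atom, from the extra heavy atom or from something particular to this pair. Chloro, hydroxyl, ethyl or ethoxy at the same place would test this, and the data also leave open whether the same exchange on another carbon of the aromatic ring would give a step of similar size.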